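The source may report more compounds than this note shows. Statements on the series, on what has been measured and on what is new or still open speak of the compounds shown alone.

Measured so far:
compound 1 `CNC(=O)CSc1nc2ccc(NC(=O)c3ccccc3)cc2s1` — 26500 nM
compound 2 `CC(=O)Nc1ccc2nc(SCC(=O)NCc3ccccc3)sc2c1` — 9200 nM

Both numbers come from a functional assay on HepG2 cells (Homo sapiens) for cytotoxicity, read by MTT assay, with a stated time of 48 h; a lower number here means a stronger inhibitor, a higher number a weaker inhibitor. Of the two, compound 2 gives the lower number, and its gap to compound 1 lies beyond the ordinary scatter of repeated runs. Going by the values given here, the two structures differ in more than one place, so no single step connects them and nothing more can be drawn from the pair.

Compound 3, `O=C(CSc1nc2ccc(NC(=O)c3ccccc3)cc2s1)NCc1ccccc1`, has not yet been tested. It is built from compound 2 by one change: phenyl in place of methyl on a carbonyl carbon. Among the compounds with values here, no measured step of this kind exists among the compounds at hand, so the direction has to be guessed. Compound 1 already carries the benzamido group and gives the higher number, but it also differs from compound 3 in its amide, so that comparison settles nothing on its own. The expected step from compound 2 to compound 3 in this assay is a 1.4-fold higher number from compound 2 to compound 3 (0.15 log units; within the scatter), a small shift that may well sit within the scatter. Compound 3 is therefore expected to give about 13000 nM, with a likely range from 4500 nM to 40000 nM.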

Compound 3, half-maximal inhibitory concentration: 34200 nM
For compound 3 the middle estimate is 2.6-fold (0.42 log units) below the measured one, within the range that was stated.
By their numbers in this assay, from the lowest: compound 2; then compounds 1 and 3 (each within the scatter of the next).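

In this assay, going by these compounds alone, turning acetamido into benzamido gives a 3.7-fold higher number from compound 2 to compound 3 (0.57 log units; beyond the scatter), the first single-change reading at this position: with everything else held fixed, phenyl on this carbonyl carbon gives a weaker result than methyl. The other new comparison keeps the benzamido group and places phenyl in place of hydrogen on a saturated chain carbon bound to an amide-type nitrogen, giving a 1.3-fold higher number from compound 1 to compound 3 (0.11 log units; within the scatter), so in this pair that change at the far amide makes no difference that can be told from the scatter. No measurement at hand explains why the swap from acetyl to benzoyl weakens the result.

The compounds shown carry only methyl or phenyl on this carbonyl carbon, so it remains open how a longer chain, a cyclohexyl ring or a phenyl ring bearing an amine would read in this assay. On these data alone, the effect of the methyl-to-phenyl change also rests on a single pair, so it is unknown whether the same step would appear with the amide end of compound 1.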